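The source may report more compounds than this note shows. Statements on the series, on what has been measured and on what is new or still open speak of the compounds shown alone.

Compound 1 `Cc1cc(NC(C)C)nc(SCc2nc3ccccc3[nH]2)n1` carries an isopropyl on a nitrogen on an aromatic ring. In a functional assay on MCF7 cells (Homo sapiens) for cytotoxicity, read by MTT assay, with a stated time of 72 h (a lower number here means a stronger inhibitor, a higher number a weaker inhibitor), compound 1 gives > 100000 nM, which is a limit of the assay and not a number. On the numbers shown, compound 1 therefore sits at the limit of > 100000 nM in this assay, at which 1 of the 2 values shown sits, the weaker end of the pair measured so far. Compound 2 `Cc1cc(Nc2ccc(Cl)cc2)nc(SCc2nc3ccccc3[nH]2)n1` gives 33600 nM in this assay. Going by the values given here, the single measured step, an at least 2.9-fold lower number from compound 1 to compound 2 (0.47 log units; beyond the scatter), puts 4-chlorophenyl in place of isopropyl on that nitrogen. Compound 3 `Cc1ccc(Nc2cc(C)nc(SCc3nc4ccccc4[nH]3)n2)cc1` is the next analogue, with the change (4-methylphenyl in place of isopropyl on a nitrogen on an aromatic ring). This mirrors the measured step in kind, exchanging isopropyl for 4-methylphenyl on a nitrogen on an aromatic ring, so a step of similar size and the same direction is expected in this assay. The expected step is an at least 2.5-fold lower number from compound 1 to compound 3 (0.39 log units; beyond the scatter), a lowering of the number. Compound 3 is thus estimated at 40000 nM, with a range from 15000 nM to 120000 nM.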

Compound 3, half-maximal inhibitory concentration: 56500 nM
The estimate for compound 3 lay 1.4-fold (0.15 log units) below the measured number, within the range that was stated.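

In this assay, methyl in place of chloro on an aromatic carbon gives a 1.7-fold higher number from compound 2 to compound 3 (0.23 log units; within the scatter), so the two para-free "aryl" labels aside, these analogues are not separated by this change. The other new step, an at least 1.7-fold lower number from compound 1 to compound 3 (0.24 log units; that floor lies within the scatter), does not on its own establish a gain for 4-methylphenyl over isopropyl on this nitrogen, so the replacement of isopropyl by an aromatic ring clears the scatter only with 4-chlorophenyl. That step can be read only as a floor because compound 1 stands at a limit, not a number: the limit of > 100000 nM in this assay, at which 1 of the 3 values shown sits.

On these data alone, whether a methoxy or a carboxylic acid on that phenyl ring would move the number beyond the scatter stays open. Also open, as far as these compounds go, is whether a longer chain such as hexyl on the nitrogen would lower the number as 4-chlorophenyl does.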